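This account rests on a few compounds, and the source may have more. Where it says the series, first, only, none or still open, it means among the compounds named here.

In a functional assay on MGC-803 cells (Homo sapiens) for antiproliferative activity, read by MTT assay, with a stated time of 72 h (a lower number here means a stronger inhibitor, a higher number a weaker inhibitor), compound 1 `O=C(N/N=C/c1ccco1)c1cccc(S(=O)(=O)N2CCOCC2)c1` reads > 100000 nM and that reading is a limit of the assay, not a number. Compound 2 `O=C(N/N=C/c1ccccc1O)c1cccc(S(=O)(=O)N2CCOCC2)c1` gives 25300 nM and compound 3 `O=C(N/N=C/c1cc(Br)ccc1O)c1cccc(S(=O)(=O)N2CCOCC2)c1` gives 14800 nM; these two numbers lie within the scatter of each other, so compound 3 stands level with compound 2 and neither ranks ahead.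

Compound 4 `O=C(N/N=C/c1cc(Br)cc(Br)c1O)c1cccc(S(=O)(=O)N2CCOCC2)c1` differs from compound 3 by bromo in place of hydrogen on an aromatic carbon with bromo in place of hydrogen on an aromatic carbon, ortho to a hydroxy group and meta to a bromo group. Replacing furan-2-yl gave an at least 3.9-fold lower number from compound 1 to compound 2 (0.59 log units; beyond the scatter) and an at least 6.7-fold lower number from compound 1 to compound 3 (0.82 log units; beyond the scatter), both beyond the scatter, but that is a different kind of change. Among the measured compounds shown here, the closest precedent is the one measured bromo step, a 1.7-fold lower number from compound 2 to compound 3 (0.23 log units; within the scatter), which lies within the scatter.

No step beyond the scatter is therefore expected in this assay. The expected change is only a 1.2-fold lower number from compound 3 to compound 4 (0.09 log units; within the scatter) and its direction is uncertain. For compound 4 the estimate is 12000 nM with an expected range of 5000 nM to 30000 nM.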

Compound 4, half-maximal inhibitory concentration: 17800 nM
The estimate for compound 4 lay 1.5-fold (0.17 log units) below the measured number, and the stated range covers the measured number.
By their numbers in this assay, from the lowest: compounds 3, 4 and 2 (each within the scatter of the next). At a limit, above all of these: compound 1.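

In this assay, bromo on the aromatic carbon ortho to a hydroxy group and meta to a bromo group gives no readable step: a 1.2-fold higher number from compound 3 to compound 4 (0.08 log units; within the scatter) and a 1.4-fold lower number from compound 2 to compound 4 (0.15 log units; within the scatter) both lie within the scatter, so compounds 2, 3 and 4 stand level at this resolution. The separation from the furan-2-yl compound also holds for 3,5-dibromo-2-hydroxyphenyl, with an at least 5.6-fold lower number from compound 1 to compound 4 (0.74 log units; beyond the scatter), which lies beyond the scatter. This step is only a bound, since compound 1 stands at a limit of the assay and not at a number: the limit of > 100000 nM in this assay, at which 1 of the 4 values shown sits.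

From the compounds shown here alone, whether an amine or a methoxy group on this same carbon would give a step beyond the scatter stays open. Also open, going by these compounds, is how the series reads with a methoxy group in place of the hydroxy group.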